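The source may hold more compounds than are shown below. What is called first, only, known or untested is meant among the compounds shown, and "the series" means these compounds.

Measured so far in a functional assay on HepG2 cells (Homo sapiens) for antiproliferative activity, read by spectrophotometry, with a stated time of 2 days; a lower number here means a stronger inhibitor of growth, a higher number a weaker inhibitor of growth:
- compound 1 (`Cc1ccc(Nc2ncc(C(F)(F)F)c(N3Cc4cccc(N(C)S(C)(=O)=O)c4C3)n2)cc1C`) gives > 30000 nM (a limit of the assay, not a number)
- compound 2 (`COc1cc(N2CCN(C(C)=O)CC2)ccc1Nc1ncc(C(F)(F)F)c(N2Cc3cccc(N(C)S(C)(=O)=O)c3C2)n1`) gives 3800 nM
- compound 3 (`CN(c1cccc2c1CN(c1nc(Nc3ccc(Nc4ccccc4)cc3)ncc1C(F)(F)F)C2)S(C)(=O)=O`) gives 8600 nM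

Compound 1 is known only as a limit: the limit of > 30000 nM in this assay, at which 1 of the 3 values shown sits. Only compound 2 and compound 3 return actual numbers.

Compound 4 (`Cc1cc(F)ccc1Nc1ncc(C(F)(F)F)c(N2Cc3cccc(N(C)S(C)(=O)=O)c3C2)n1`) keeps the core of compound 1 and has 4-fluoro-2-methylphenyl in place of 3,4-dimethylphenyl on a nitrogen on an aromatic ring. Among the compounds with values here, no measured pair differs in one place, so this change has no direct precedent.

The expectation in this assay rests on compound 1 at > 30000 nM, itself a limit. The expected change is an at least 1.2-fold lower number from compound 1 to compound 4 (0.07 log units; that floor lies within the scatter), with no step beyond the scatter in either direction. Compound 4 may well return only a limit too. For compound 4 the estimated value is 25000 nM, with an expected range from 9000 nM to 50000 nM.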

Compound 4, concentration for 50% growth inhibition: 16800 nM
Beside the measured number, compound 4's estimate is 1.5-fold (0.17 log units) above it; the range from low to high includes it.
By their numbers in this assay, from the lowest: compound 2; then compounds 3 and 4 (each within the scatter of the next). At a limit, above all of these: compound 1.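

In this assay, compound 4 gives 16800 nM, so this position on the core of compound 1 can return an actual number when the aryl group is 4-fluoro-2-methylphenyl. Replacing 3,4-dimethylphenyl with that group on a nitrogen on an aromatic ring gives an at least 1.7-fold lower number from compound 1 to compound 4 (0.25 log units; that floor lies within the scatter), and this floor alone does not establish a change beyond the scatter. The true size of the step stays open because compound 1 is known only as a limit: the limit of > 30000 nM in this assay, at which 1 of the 4 values shown sits.

What the fluorine and the methyl of 4-fluoro-2-methylphenyl each contribute to the step remains unresolved. Also open, going by these compounds, is how a morpholine or a carboxylic acid on this phenyl ring would read against compound 4 in this assay.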